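From compound 2 to compound 3: working notes

This account rests on a few compounds, and the source may have more. Where it says the series, first, only, none or still open, it means among the compounds named here.

Measured in an ADME assay on CCRF-CEM cells (Homo sapiens) for cytotoxicity; a higher number here means that more compound is tolerated, a lower number that less compound is tolerated:
Compound 1 `CC(C)C[C@@H](CO)NC(=O)c1cnc2ccccc2c1Cl`: > 100 uM (a limit)
Compound 2 `COC(=O)CNC(=O)c1cnc2ccccc2c1Cl`: > 100 uM (a limit)

In this assay compound 2 gives > 100 uM, which is a limit and not a number. Among the compounds with values here, the same holds for the other measured compound, so the series so far shows only (the limit of > 100 uM in this assay, at which 2 of the 2 values shown sit). Within the data shown here, the one measured step is a step that the two limits leave unreadable from compound 1 to compound 2, with (methoxycarbonyl)methyl in place of 1-(hydroxymethyl)-3-methylbutyl on an amide-type nitrogen. It gives no size to carry forward.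

Compound 3 `COC(=O)[C@H](CSC)NC(=O)c1cnc2ccccc2c1Cl` differs from compound 2 by (methylsulfanyl)methyl in place of hydrogen on a saturated chain carbon bound to an amide-type nitrogen and a carbonyl carbon. Among the measured compounds shown here, no measured step covers this change directly. For the measured compounds named here, the only guide is that compound 1 and compound 2, with different groups on the amide-type nitrogen, both rest at the same limit. No step beyond the scatter is therefore expected, and compound 3 is expected to be reported as a limit as well. The expected step is a number no higher from compound 2 to compound 3 (the limit leaves the size open). For compound 3 the estimate in this assay is 100 uM, with an expected range from 50 uM to 200 uM.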

Compound 3, half-maximal toxic concentration: 68.4 uM
Compound 3: the middle estimate sits 1.5-fold (0.16 log units) above what was measured; the measured number falls inside the stated range.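

In this assay, within the data shown here, compound 3 gives 68.4 uM as the only actual number so far, which makes the saturated chain carbon bound to an amide-type nitrogen and a carbonyl carbon the first position where a change yields a readable value. The change of (methylsulfanyl)methyl in place of hydrogen at this carbon gives an at least 1.4-fold lower number from compound 2 to compound 3 (0.16 log units; that floor lies within the scatter) and so has only a floor for its size, one that does not on its own separate compound 3 from compound 2. The step from compound 1 to compound 2 cannot be read, and the other two compounds remain at a limit of the assay, not at a number: the limit of > 100 uM in this assay, at which 2 of the 3 values shown sit.

From the compounds shown here alone, it stays open whether the value of compound 3 is specific to the sulfur-bearing group or would also appear with a plain methyl or a longer chain such as 2-(methylsulfanyl)ethyl on the same carbon. It is equally open how a carboxylic acid in place of the methyl ester would read with (methylsulfanyl)methyl in place, as no such compound is among those shown.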